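Nitrofuran amide series: a pyrrolidine variant on the core

The compounds below may be only part of what the source reports. "The series", "measured", "known", "first", "only" and "open" are said of these compounds alone.

Measured compounds:
compound 1 `CN1CCN(c2ccn3c(-c4ccc(NC(=O)c5ccc([N+](=O)[O-])o5)cc4)cnc3c2)CC1`: 1580 nM
compound 2 `O=C(Nc1ccc(-c2cnc3cc(N4CCN(C5CC5)CC4)ccn23)cc1)c1ccc([N+](=O)[O-])o1`: 1650 nM
compound 3 `O=C(Nc1ccc(-c2cnc3cc(C4=CCN(C5COC5)CC4)ccn23)cc1)c1ccc([N+](=O)[O-])o1`: 1100 nM

All three numbers come from a functional assay on MGC-803 cells (Homo sapiens) for antiproliferative activity, read by CCK-8 assay, with a stated time of 72 h; on this read-out lower numbers stand for stronger inhibition and higher numbers for weaker inhibition. Compound 1 stands second highest of the three. The nearest step is a 1.0-fold higher number from compound 1 to compound 2 (0.02 log units; within the scatter); the furthest is a 1.4-fold lower number from compound 1 to compound 3 (0.16 log units; within the scatter). Both stay within the scatter, as does a 1.5-fold lower number from compound 2 to compound 3 (0.18 log units; within the scatter).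

Compound 4 `O=C(Nc1ccc(-c2cnc3cc(N4CCCC4)ccn23)cc1)c1ccc([N+](=O)[O-])o1` has not been measured. It differs from compound 1 by pyrrolidin-1-yl in place of 4-methylpiperazin-1-yl on an aromatic carbon. The measured steps that bear on it replace the same group on the same aromatic carbon, and none of them moves beyond the scatter, so a change of this kind is expected to give no step beyond the scatter: a 1.1-fold lower number from compound 1 to compound 4 (0.02 log units; within the scatter) is the expected step. Compound 4 is therefore estimated at 1500 nM in this assay, expected to lie between 700 nM and 3200 nM.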

Compound 4, half-maximal inhibitory concentration: 1150 nM
For compound 4 the middle estimate is 1.3-fold (0.12 log units) above the measured one; measured number inside the range.
By their numbers in this assay, from the lowest: compounds 3, 4, 1 and 2 (each within the scatter of the next).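

In this assay, pyrrolidin-1-yl on this aromatic carbon, with one ring nitrogen and no group on a second one, gives no step beyond the scatter from either piperazine: a 1.4-fold lower number from compound 1 to compound 4 (0.14 log units; within the scatter) and a 1.4-fold lower number from compound 2 to compound 4 (0.16 log units; within the scatter). The step to the tetrahydropyridine of compound 3 stays within the scatter too (a 1.0-fold higher number from compound 3 to compound 4 (0.02 log units; within the scatter)), so this position accepts all four groups shown with little change in the number. No measurement here accounts for these small steps.

Open, as far as these compounds go, is whether any group on this carbon moves the number beyond the scatter. A primary amine, a carboxylic acid or a longer chain there would test this.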